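The source may report more compounds than this note shows. Statements on the series, on what has been measured and on what is new or still open speak of the compounds shown alone.

Compound 1 `C=CC(=O)Nc1cccc(NC(=O)CSc2nc(Nc3ccccc3)c3ccccc3n2)c1` gives 7310 nM in a functional assay on MGC-803 cells (Homo sapiens) for inhibition, read by MTT assay, with a stated time of 72 h; a lower number here means a stronger inhibitor, a higher number a weaker inhibitor. Compound 2 `C=CC(=O)Nc1cccc(NC(=O)CSc2nc(Nc3cccc(F)c3)c3ccccc3n2)c1` gives 6250 nM in this assay.

Compound 2 and compound 1 sit within the scatter of each other, the step of a 1.2-fold lower number from compound 1 to compound 2 (0.07 log units; within the scatter). Compound 3 `C=CC(=O)Nc1cccc(NC(=O)CSc2nc(Nc3cccc(OC)c3)c3ccccc3n2)c1` differs from compound 2 by methoxy in place of fluoro on an aromatic carbon. Going by the values given here, the only measured step touches the same aromatic carbon, where fluoro in place of hydrogen gave a 1.2-fold lower number from compound 1 to compound 2 (0.07 log units; within the scatter); no measured step speaks to methoxy. Compound 3 is therefore expected to move by a 1.0-fold lower number from compound 2 to compound 3 (0.02 log units; within the scatter), nothing beyond the scatter. Compound 3 is estimated at 6000 nM, with a range from 2500 nM to 15000 nM.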

Compound 3, half-maximal inhibitory concentration: 24200 nM
Beside the measured number, compound 3's estimate is 4.0-fold (0.61 log units) below it, and the stated range ends below it.
By their numbers in this assay, from the lowest: compounds 2 and 1 (each within the scatter of the next); then compound 3.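

This aromatic carbon, silent to fluoro in place of hydrogen, is not indifferent to every group: in this assay methoxy in place of fluoro gives a 3.9-fold higher number from compound 2 to compound 3 (0.59 log units; beyond the scatter), and methoxy in place of hydrogen gives a 3.3-fold higher number from compound 1 to compound 3 (0.52 log units; beyond the scatter). Compound 3 is thus the weakest of the three, with both of its steps beyond the scatter. Nothing available explains this change. Going by these compounds, whether a methyl, a hydroxyl or an amine on this carbon would stay level with hydrogen and fluoro or fall with methoxy remains open.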